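A side-chain swap at the weak end of the numbers

The compounds below may be only part of what the source reports. "The series", "measured", "known", "first", "only" and "open" are said of these compounds alone.

In a functional assay (HSMC cells, Homo sapiens) for antiproliferative activity, with a stated time of 72 h (a higher number here means a weaker inhibitor, a lower number a stronger inhibitor), compound 1 `COC(=O)[C@H](CCSC)NC(=O)c1ccc(C(=O)NC[C@H]2COc3ccccc3O2)cc1-c1ccccc1C` gives 87000 nM, while compound 2 `COC(=O)[C@H](CCSC)NC(=O)c1ccc(C(=O)NC[C@H]2COc3ccccc3O2)cc1-c1ccccc1OC` gives 252000 nM. Compound 2 therefore holds the higher of the two numbers and is the weaker inhibitor of the pair. The next structure, compound 3 `COC(=O)[C@H](CC(C)C)NC(=O)c1ccc(C(=O)NC[C@H]2COc3ccccc3O2)cc1-c1ccccc1OC`, keeps the methoxy group of compound 2 and changes the other end of the molecule: isopropyl in place of (methylsulfanyl)methyl on a saturated chain carbon, two bonds along the chain from an amide-type nitrogen and a carbonyl carbon. The swap puts isopropyl in place of (methylsulfanyl)methyl on a saturated chain carbon. Within the data shown here, no measured step touches this carbon. Among the measured compounds shown here, the only step available, a 2.9-fold higher number from compound 1 to compound 2 (0.46 log units; beyond the scatter), is modest and lies on an aromatic carbon, so it offers just a rough guide to size. In this assay, a small change of uncertain direction is expected, probably within the scatter. For compound 3 the estimate is 200000 nM, with an expected range from 80000 nM to 500000 nM. This estimate means an expected 1.3-fold lower number from compound 2 to compound 3 (0.10 log units; within the scatter).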

Compound 3, half-maximal inhibitory concentration: 185000 nM
Compound 3: middle estimate off by 1.1-fold (0.03 log units), on the high side; the range from low to high includes it.
By their numbers in this assay, from the lowest: compound 1; then compounds 3 and 2 (each within the scatter of the next).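

In this assay the swap of (methylsulfanyl)methyl for isopropyl gives a 1.4-fold lower number from compound 2 to compound 3 (0.13 log units; within the scatter) and so leaves the two compounds indistinguishable. Among these compounds, this is the only measured step at this saturated chain carbon, and it shows that, with the methoxy group held fixed, the sulfur and the single hydrogen-bond acceptor of the leaving group can go without a change that stands clear of the scatter. No measurement bears on why the two groups read alike.

The compounds shown leave open whether the same swap would read alike with the methyl group of compound 1 in place of the methoxy group. They also leave open whether an amine or a longer chain at this carbon, or a carboxylic acid in place of the methoxycarbonyl group, would move the number beyond the scatter.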